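The source may report more compounds than this note shows. Statements on the series, on what has been measured and on what is new or still open speak of the compounds shown alone.

This study concerns a family of compounds built on one shared core and judged in an ADME assay on HepG2 cells (Homo sapiens) for cytotoxicity, read by MTT assay, with a stated time of 72 h; a higher number here means that more compound is tolerated, a lower number that less compound is tolerated. Going by the values given here, compound 1 `CC1(Cc2ccccc2)CC(S(=O)(=O)c2cccc(C(F)(F)F)c2)=C(c2ccc(/C(N)=N\O)cc2)O1` gives 33400 nM in this assay, and it is the only compound here with a number rather than a limit. Compound 2 `CC1(c2ccc(-c3cccc([N+](=O)[O-])c3)cc2)CC(S(=O)(=O)c2ccc(F)cc2)=C(c2ccc(/C(N)=N\O)cc2)O1` reaches the limit of the assay, with > 50000 nM in this assay. What the set offers as evidence amounts to the limit of > 50000 nM in this assay, at which 1 of the 2 values shown sits. Compound 3 `CC1(Cc2ccccc2)CC(S(=O)(=O)c2ccc(F)cc2F)=C(c2ccc(/C(N)=N\O)cc2)O1` has not yet been tested in this assay. It differs from compound 1 by 2,4-difluorophenyl in place of 3-(trifluoromethyl)phenyl on a sulfonyl sulfur. Among the compounds with values here, no step between two measured compounds is available to guide the expectation, and the change is therefore weighed on its own; a step no larger than the usual scatter is expected, if anything toward more compound being tolerated. The expected step from compound 1 to compound 3 is a 1.2-fold higher number from compound 1 to compound 3 (0.08 log units; within the scatter). Compound 3 is accordingly estimated to give 40000 nM in this assay, with a range from 15000 nM to 100000 nM.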

Compound 3, half-maximal cytotoxic concentration: 90600 nM
Compound 3: the middle estimate sits 2.3-fold (0.36 log units) below what was measured, and the stated range covers the measured number.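

In this assay the group on the sulfonyl sulfur matters: 2,4-difluorophenyl in place of 3-(trifluoromethyl)phenyl gives a 2.7-fold higher number from compound 1 to compound 3 (0.43 log units; beyond the scatter) with the rest of the molecule unchanged. Going by these compounds alone, this is the first step in the set between two measured compounds that differ in one place, and it shows that a change at this place alone can move the number beyond the usual scatter, here toward more compound being tolerated. No measurement shown gives a reason for this step, so it stands as an observation only.

This single swap changes the ring's substituents in number and kind at once, so it cannot show whether gaining the two fluorines or losing the trifluoromethyl group matters more. As far as these compounds go, a plain phenyl ring or a phenyl ring carrying an amine on the same sulfonyl sulfur would be needed to separate the two, and how either would behave remains open.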